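This account rests on a few compounds, and the source may have more. Where it says the series, first, only, none or still open, it means among the compounds named here.

Three compounds built on the shared core of compound 1 have been tested in an in vitro functional assay on cells (Fibroblast) for agonist activity at Alpha-1D adrenergic receptor (Homo sapiens); on this read-out higher numbers stand for an effect only at larger amounts of compound and lower numbers for an effect already at smaller amounts. Going by the values given here, compound 1, `CCCn1ncnc1-c1ccccc1NCC1=NCCN1`, is the only one with a firm number: in this assay compound 1 gives 251 nM. Compound 2, `CC(C)n1nccc1-c1ccccc1NCC1=NCCN1`, reached only a limit of the assay, and in this assay compound 2 gives < 100000 nM. Compound 3, `Cc1nc(-c2ccccc2NCC2=NCCN2)n(C)n1`, likewise reached only a limit of the assay, with compound 3 giving < 5020 nM in this assay. These two results are limits rather than numbers, so they cannot be set against compound 1. Among the compounds with values here, no measured step between compounds is available.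

The unmeasured compound 4, `CCn1ncnc1-c1ccccc1NCC1=NCCN1`, differs from compound 1 in a single place: hydrogen in place of methyl on a saturated chain carbon, two bonds along the chain from an aromatic nitrogen. Trimming propyl to ethyl on a saturated chain carbon, two bonds along the chain from an aromatic nitrogen, is a small alteration, and nothing among the measured compounds shows how such a change moves the read-out. The expected step in this assay is therefore a 1.2-fold higher number from compound 1 to compound 4 (0.08 log units; within the scatter), a shift no larger than the usual scatter in either direction. On that basis compound 4 is estimated to give 300 nM in this assay, with a plausible range from 100 nM to 1000 nM.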

Compound 4, half-maximal effective concentration: 126 nM
Compound 4: middle estimate off by 2.4-fold (0.38 log units), on the high side, within the range that was stated.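

Trimming propyl to ethyl at this place, on a saturated chain carbon two bonds along the chain from an aromatic nitrogen, gives a 2.0-fold lower number from compound 1 to compound 4 (0.30 log units; within the scatter) in this assay. Going by these compounds alone, this is the first measured step, which until now held one firm number and two limits, so it is the first direct look at what this change does. The two compounds lie within the usual scatter of each other, so at this place the loss of one methyl leaves the read-out without a change that can be told from repeat-to-repeat noise, and nothing measured here bears on why that is so.

On these data alone, one step between two chain lengths cannot show a trend, so whether a butyl chain, or a chain ending in an amine or a carboxylic acid, would hold the read-out in the same range stays open. Compound 2 and compound 3 stand only as limits of the assay and so give no further firm number to set against this step.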